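Aryl ether to neopentyl ether in the antiproliferative series

The compounds below may be only part of what the source reports. "The series", "measured", "known", "first", "only" and "open" are said of these compounds alone.

Measured compounds:
compound 1 `CCS(=O)(=O)Nc1ccc(Oc2ccc(C#N)cc2)c(-c2cn(C)c(=O)c3[nH]ccc23)c1` — 17 nM
compound 2 `CCS(=O)(=O)Nc1ccc(Oc2ccc(C(F)(F)F)cc2)c(-c2cn(C)c(=O)c3[nH]ccc23)c1` — 30 nM

In a functional assay on MX1 cells (Homo sapiens) for antiproliferative activity, with a stated time of 72 h (a higher number here means that more compound is needed for the effect, a lower number that less compound is needed), compound 1 gives 17 nM and compound 2 gives 30 nM. The only measured step, a 1.8-fold higher number from compound 1 to compound 2 (0.25 log units; within the scatter), lies within the scatter, so compound 2 stands level with compound 1 on the two numbers shown; neither can be called more or less active than the other.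

Compound 3 `CCS(=O)(=O)Nc1ccc(OCC(C)(C)C)c(-c2cn(C)c(=O)c3[nH]ccc23)c1` differs from compound 2 by neopentyl in place of 4-(trifluoromethyl)phenyl on an oxygen on an aromatic ring. For the measured compounds named here, the one measured step varies only the substituent on the phenyl ring that leaves here; no measured step removes that ring or puts a chain in its place, so the size of the step to compound 3 is not anchored by the data and the range is set wide. Compound 3 is expected to give 100 nM, with a range from 20 nM to 600 nM. The expected step is a 3.3-fold higher number from compound 2 to compound 3 (0.52 log units; beyond the scatter), a loss that may or may not exceed the scatter.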

Compound 3, half-maximal effective concentration: 77 nM
Compound 3: middle estimate off by 1.3-fold (0.11 log units), on the high side; low and high end bracket the measured number.
By their numbers in this assay, from the lowest: compounds 1 and 2 (each within the scatter of the next); then compound 3.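

Replacing the aromatic ring on the ether oxygen with a chain costs only a modest amount in this assay: neopentyl in place of 4-(trifluoromethyl)phenyl gives a 2.6-fold higher number from compound 2 to compound 3 (0.41 log units; beyond the scatter), and neopentyl in place of 4-cyanophenyl gives a 4.5-fold higher number from compound 1 to compound 3 (0.66 log units; beyond the scatter). Both steps lie beyond the scatter, so this position responds to the change of group in a way the within-scatter step between the two aryl ethers did not show, yet an aromatic ring here is not required, as compound 3 still gives 77 nM. No available data speak to the origin of this loss.

From the compounds shown here alone, whether the loss comes from removing the ring or from the particular chain stays open. A cyclohexyl ring, a shorter chain such as ethyl, or a chain carrying an amine on the same oxygen would separate these readings.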